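Swapping a urea for a naphthyl amide on a shared core

The source may hold more compounds than are shown below. What is called first, only, known or untested is meant among the compounds shown, and "the series" means these compounds.

Measured so far:
- compound 1, `CN1CCC(C(=O)N2Cc3c(NC(=O)Nc4cccc(F)c4)n[nH]c3C2(C)C)CC1`: 350 nM
- compound 2, `CC(C)(C)C(=O)N1Cc2c(NC(=O)c3cccnc3)n[nH]c2C1(C)C`: 690 nM
- compound 3, `CC1(C)c2[nH]nc(NC(=O)c3ccc(F)cc3)c2CN1C(=O)N1CCN(c2ccccc2)CC1`: "not determined" (no result reported)

All three compounds share the same core and differ in the groups hung on it. In a functional assay on A2780 cells (Homo sapiens) for antiproliferative activity, read by fluorescence, with a stated time of 72 h (a lower number here means a stronger inhibitor, a higher number a weaker inhibitor), compound 1 gives 350 nM, the lowest of the two numbers available. In this assay compound 2 gives 690 nM, which lies within the usual scatter of compound 1, so the two cannot be ranked against each other. In this assay compound 3 gives "not determined" (no result reported), so no number is available for it.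

Compound 4, `CN1CCC(C(=O)N2Cc3c(NC(=O)c4ccc5ccccc5c4)n[nH]c3C2(C)C)CC1`, is a variation of compound 1: naphthalen-2-yl in place of (3-fluorophenyl)amino on a carbonyl carbon. The urea link of compound 1 thus becomes an amide, and a single fluorinated ring becomes a two-ring system.

Within the data shown here, no pair of measured compounds isolates this change, so the expectation is rough. Compound 2, which also carries an amide on this core, sits within the scatter of compound 1 in this assay, and nothing in the data points toward a large move in either direction. The expected step from compound 1 to compound 4 in this assay is therefore a 1.4-fold higher number from compound 1 to compound 4 (0.15 log units; within the scatter), within the scatter. Compound 4 is estimated at 500 nM, in the range 120 nM to 2000 nM.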

Compound 4, half-maximal inhibitory concentration: 270 nM
Estimate against measurement, compound 4: 1.9-fold (0.27 log units) above, and the stated range covers the measured number.
By their numbers in this assay, from the lowest: compounds 4, 1 and 2 (each within the scatter of the next, the first and the last beyond it).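

Among these compounds, compound 1 and compound 4 form the first measured pair that differs in only one place: naphthalen-2-yl in place of (3-fluorophenyl)amino on a carbonyl carbon gives a 1.3-fold lower number from compound 1 to compound 4 (0.11 log units; within the scatter) in this assay and stays within the scatter. This place therefore accepts a group of two carbon-only aromatic rings, and for this pair neither the urea link nor the fluorine is required to keep the number in this range. No measured property of these groups is available to explain the result.

A single change of this kind cannot separate the effect of the urea link from that of the second ring, and a plain phenyl on the same carbonyl carbon would help to tell them apart. From the compounds shown here alone, whether a morpholine or a carboxylic acid would be accepted in this place also remains open.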